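The compounds below may be only part of what the source reports. "The series", "measured", "known", "first", "only" and "open" are said of these compounds alone.

Of the compounds shown here, three from one series have been measured in a functional assay on DU-145 cells (Homo sapiens) for inhibition, read by trypan blue exclusion, with a stated time of 96 h; on this read-out higher numbers stand for weaker inhibition of growth and lower numbers for stronger inhibition of growth. Compound 1 `O=C(/C(=C\c1ccc([N+](=O)[O-])c(O)c1)SCc1ccc(Br)cc1)c1cc(Cl)ccc1O` gives 10000 nM, compound 2 `O=C(/C(=C\c1ccc(OC(F)(F)F)cc1)S(=O)(=O)c1ccc(Br)cc1)c1ccc(Br)cc1` gives 25000 nM, and compound 3 `O=C(/C(=C\c1ccc(F)cc1)S(=O)(=O)c1ccc(Br)cc1)c1ccc(Br)cc1` gives 4000 nM. Compound 3 thus stands lowest of the three numbers, with compound 1 nearest and compound 2 furthest. Compound 4 `COc1ccc(/C=C(\C(=O)c2ccc(Br)cc2)S(=O)(=O)c2ccc(Br)cc2)c(F)c1` is still to be measured; it differs from compound 3 by 2-fluoro-4-methoxyphenyl in place of 4-fluorophenyl on a double-bonded chain carbon bound to a double-bonded chain carbon. Among the measured compounds shown here, the one measured step, a 6.3-fold lower number from compound 2 to compound 3 (0.80 log units; beyond the scatter), swaps a different group on the same ring; it bears only loosely on the present change. In this assay the change is expected to amount to a 1.5-fold higher number from compound 3 to compound 4 (0.18 log units; within the scatter), with no direction that the data secure. Compound 4 is estimated at 6000 nM, within a range from 2000 nM to 18000 nM.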

Compound 4, concentration for 50% growth inhibition: 10000 nM
For compound 4 the middle estimate is 1.7-fold (0.22 log units) below the measured one; measured number inside the range.
By their numbers in this assay, from the lowest: compound 3; then compounds 1 and 4 (each within the scatter of the next); then compound 2.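

In this assay, 2-fluoro-4-methoxyphenyl in place of 4-fluorophenyl on a double-bonded chain carbon bound to a double-bonded chain carbon gives a 2.5-fold higher number from compound 3 to compound 4 (0.40 log units; beyond the scatter). With a 6.3-fold lower number from compound 2 to compound 3 (0.80 log units; beyond the scatter), this leaves the 4-fluorophenyl of compound 3 with the lowest number among the three groups tried at this place on the shared core. No measurement shown gives a reason for this rise.

Going by these compounds, the fluoro and methoxy groups differ together here, so their separate contributions stay open. Also open, on these data alone, is how a carboxylic acid or an amine-bearing phenyl would stand at this place.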